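Working notes: the step from compound 2 to compound 3

The compounds below may be only part of what the source reports. "The series", "measured", "known", "first", "only" and "open" are said of these compounds alone.

- compound 1 (`COc1cc(NC(C)CCCNC(=O)NNC(=O)NCCO)c2ncccc2c1`) in a functional assay on MIA PaCa-2 cells (Homo sapiens) for inhibition, read by MTT assay, with a stated time of 4 days (on this read-out higher numbers stand for weaker inhibition and lower numbers for stronger inhibition), gives >= 250000 nM as a limit
- compound 2 (`COc1cc(NC(C)CCCNC(=O)NNC(=O)NC(CO)(CO)CO)c2ncccc2c1`) in this assay gives > 250000 nM as a limit

Going by the values given here, compound 2 stands only at a limit, and so does the one other value shown. Compound 3 (`COc1cc(NC(C)CCCNC(=O)Nc2ccc(Cl)c(C(F)(F)F)c2)c2ncccc2c1`) carries 4-chloro-3-(trifluoromethyl)phenyl in place of ((2-hydroxy-1,1-bis(hydroxymethyl)ethyl)carbamoyl)amino on an amide-type nitrogen. Among the compounds with values here, the only measured step (a step that the two limits leave unreadable from compound 1 to compound 2) has no readable size, so it sets no scale for this change. Compound 2 sits at its limit (> 250000 nM) in this assay, which leaves room in one direction only. A step toward stronger inhibition is therefore expected (an at least 20-fold lower number from compound 2 to compound 3 (1.31 log units; beyond the scatter)), its size a loose judgement. For compound 3 the estimated value is 12000 nM (expected range 3000 nM to 50000 nM).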

Compound 3, half-maximal inhibitory concentration: 4000 nM
For compound 3 the middle estimate is 3.0-fold (0.48 log units) above the measured one; measured number inside the range.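

In this assay, 4-chloro-3-(trifluoromethyl)phenyl on the amide-type nitrogen brings an at least 62-fold lower number from compound 2 to compound 3 (1.79 log units; beyond the scatter), and an at least 62-fold lower number from compound 1 to compound 3 (1.79 log units; beyond the scatter). Going by these compounds alone, the step between compound 1 and compound 2 cannot be read, so this is the first change at this position with a readable direction. Neither size is exact, because the starting values are limits: the limit of > 250000 nM in this assay, at which 1 of the 3 values shown sits; the limit of >= 250000 nM in this assay, at which 1 of the 3 values shown sits.

The compounds shown do not separate the aromatic ring from its chloro and trifluoromethyl substituents: an unsubstituted phenyl or a 4-chlorophenyl on the same nitrogen would do so. On these data alone, how a carboxylic acid at this place would read also stays open.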